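The source may report more compounds than this note shows. Statements on the series, on what has been measured and on what is new or still open speak of the compounds shown alone.

compound 1 `O=C(/C=C/c1cn(-c2ccccc2)nc1-c1cccnc1)c1ccsc1`: 500 nM
compound 2 `COc1ccc(C(=O)/C=C/c2cn(-c3ccccc3)nc2-c2cccnc2)c(OC)c1OC`: 1400 nM

In a functional assay on MCF7 cells (Homo sapiens) for inhibition, read by sulforhodamine B assay, with a stated time of 72 h (a higher number here means a weaker inhibitor, a lower number a stronger inhibitor), compound 2 gives the higher of the two numbers, with compound 1 at 500 nM standing beyond the scatter below it. Compound 3 `COc1ccc(C(=O)/C=C/c2cn(-c3ccccc3)nc2-c2cccnc2)cc1OC` differs from compound 2 by hydrogen in place of methoxy on an aromatic carbon. For the measured compounds named here, no measured pair shows the effect of such a change in this assay, so no direction can be read from the numbers at hand; a step within the scatter is expected, a 1.2-fold lower number from compound 2 to compound 3 (0.07 log units; within the scatter). Compound 3 is accordingly estimated at 1200 nM, with a range from 400 nM to 3500 nM.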

Compound 3, half-maximal inhibitory concentration: 1700 nM
Compound 3: the middle estimate sits 1.4-fold (0.15 log units) below what was measured, and the stated range covers the measured number.
By their numbers in this assay, from the lowest: compound 1; then compounds 2 and 3 (each within the scatter of the next).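

In this assay, hydrogen in place of methoxy on this aromatic carbon gives a 1.2-fold higher number from compound 2 to compound 3 (0.08 log units; within the scatter) and so leaves the number within the scatter, which means this methoxy group is dispensable in this assay. The group on the carbonyl carbon shows the larger step, with 3,4-dimethoxyphenyl in place of thiophen-3-yl giving a 3.4-fold higher number from compound 1 to compound 3 (0.53 log units; beyond the scatter) beyond the scatter. No measurement at hand bears on the cause of either step.

As far as these compounds go, whether an amine or a hydroxyl group on this aromatic carbon would also stay within the scatter remains open. So does whether thiophen-3-yl keeps its lower number with a pyridine or a furan ring on the carbonyl carbon.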